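Benzyloxy aryl variation on a shared core

The compounds below may be only part of what the source reports. "The series", "measured", "known", "first", "only" and "open" are said of these compounds alone.

Measured compounds:
compound 1 `Cc1nn(-c2ncnc3nc[nH]c23)c2c1C(OCc1ccc(Cl)cc1Cl)CC(=O)N2` gives 4 nM
compound 2 `Cc1nn(-c2ncnc3nc[nH]c23)c2c1C(C(=O)NCc1ccccc1)CC(=O)N2` gives 5 nM
compound 3 `Cc1nn(-c2ncnc3nc[nH]c23)c2c1C(OCc1ccc(C(C)C)cc1)CC(=O)N2` gives 5 nM

All three were tested in a functional assay on HEK293 cells for agonist activity at G-protein coupled receptor 39 (Homo sapiens), read by scintillation proximity assay and inositol phosphate accumulation, with a stated time of 75 min, in the presence of a further agent that is not named here; a lower number here means that less compound is needed, a higher number that more compound is needed for the effect. Compound 1 gives the lowest of the three numbers, but both neighbours sit within the scatter: a 1.3-fold higher number from compound 1 to compound 2 (0.10 log units; within the scatter), and a 1.3-fold higher number from compound 1 to compound 3 (0.10 log units; within the scatter). Nothing in the set separates these compounds from one another.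

Compound 4 `Cc1nn(-c2ncnc3nc[nH]c23)c2c1C(OCc1ccc(F)cc1)CC(=O)N2` is not yet measured. It differs from compound 1 as follows: 4-fluorophenyl in place of 2,4-dichlorophenyl on a saturated chain carbon bound to an oxygen on a saturated carbon. The step that bears on this most directly is from compound 1 to compound 3, where the aryl part of the benzyloxy group was exchanged without effect beyond the scatter. The step from compound 1 to compound 2 replaced the whole benzyloxy group with a benzylcarbamoyl group and likewise stayed within the scatter. Both point the same way: the numbers in this set are insensitive to what sits on the saturated chain carbon bound to the oxygen, so for compound 4 no step beyond the scatter is expected in this assay, that is a 1.5-fold higher number from compound 1 to compound 4 (0.18 log units; within the scatter). Compound 4 is accordingly estimated at 6 nM, with a range from 2 nM to 20 nM.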

Compound 4, half-maximal effective concentration: 1 nM
Compound 4: the middle estimate sits 6.0-fold (0.78 log units) above what was measured; measured number below the stated range.
By their numbers in this assay, from the lowest: compound 4; then compounds 1, 2 and 3 (each within the scatter of the next).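

Working note on this assay: the aryl part of the benzyloxy group does register in this series, and 4-fluorophenyl in place of 2,4-dichlorophenyl gives a 4.0-fold lower number from compound 1 to compound 4 (0.60 log units; beyond the scatter) on the same saturated chain carbon bound to an oxygen, whereas the exchange for 4-isopropylphenyl at this place stayed within the scatter. The change of fluoro for isopropyl on an aromatic carbon gives a 5.0-fold lower number from compound 3 to compound 4 (0.70 log units; beyond the scatter) and the change of (4-fluorobenzyl)oxy for benzylcarbamoyl on a saturated ring carbon gives a 5.0-fold lower number from compound 2 to compound 4 (0.70 log units; beyond the scatter) as well, so compound 4 is set apart from compounds 1, 2 and 3, which remain within the scatter of one another. No supporting measurement is available to explain this difference.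

The compounds shown do not separate the entry of fluoro at this aryl group from the departure of the chlorines of 2,4-dichlorophenyl. On these data alone, how a 4-chlorophenyl, an unsubstituted phenyl or a 4-methoxyphenyl group would read at this place remains open, as does whether fluoro gives a comparable step on the benzylcarbamoyl series.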